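This account rests on a few compounds, and the source may have more. Where it says the series, first, only, none or still open, it means among the compounds named here.

Three compounds built on the same core have been run in a functional assay on MOLT-4 cells (Homo sapiens) for antiproliferative activity; a higher number here means a weaker inhibitor, a lower number a stronger inhibitor. Compound 1 `COc1cc(C(=O)c2sc(-c3ccc([N+](=O)[O-])cc3)cc2N)cc(OC)c1OC` gives 110 nM. Compound 2 `COc1cc(C(=O)c2sc(-c3ccccc3Cl)cc2N)cc(OC)c1OC` gives 17 nM, and compound 3 `COc1cc(C(=O)c2sc(-c3cc(OC)c(OC)c(OC)c3)cc2N)cc(OC)c1OC` gives 1200 nM. Compound 2 therefore holds the lowest number of the three, with compound 1 nearest to it and compound 3 furthest away. The single one-place step among these compounds, a 6.5-fold lower number from compound 1 to compound 2 (0.81 log units; beyond the scatter), shows a modest but clear drop in the number when 2-chlorophenyl takes the place of 4-nitrophenyl on an aromatic carbon.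

Compound 4 `COc1cc(C(=O)c2sc(-c3ccc(C(F)(F)F)cc3)cc2N)cc(OC)c1OC` has not yet been measured. It differs from compound 2 in one place: 4-(trifluoromethyl)phenyl in place of 2-chlorophenyl on an aromatic carbon. Going by the values given here, the only measured step that bears on this exchange is a 6.5-fold lower number from compound 1 to compound 2 (0.81 log units; beyond the scatter), which swapped the group on that same aromatic carbon, and in that step 2-chlorophenyl gave the lower number. Removing 2-chlorophenyl again is expected to move the number back upward, so the step of a 5.9-fold higher number from compound 2 to compound 4 (0.77 log units; beyond the scatter) is estimated as a rise beyond the scatter. Compound 4 is accordingly estimated at 100 nM, with a likely range from 30 nM to 350 nM.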

Compound 4, half-maximal inhibitory concentration: 250 nM
Beside the measured number, compound 4's estimate is 2.5-fold (0.40 log units) below it; the range from low to high includes it.
By their numbers in this assay, from the lowest: compound 2; then compound 1; then compound 4; then compound 3.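

Exchanging 2-chlorophenyl for 4-(trifluoromethyl)phenyl gives a large rise in this assay (a 15-fold higher number from compound 2 to compound 4 (1.17 log units; beyond the scatter)). This aromatic carbon next to the ring sulfur is therefore sensitive to which substituted phenyl group it carries, and the earlier advantage of 2-chlorophenyl over 4-nitrophenyl now also holds against a second group. Trifluoromethyl in place of nitro gives a smaller, modest change (a 2.3-fold higher number from compound 1 to compound 4 (0.36 log units; beyond the scatter)), and both compounds stay well behind compound 2.

Still open, on these data alone, is whether the low number depends on the chlorine itself or on where it sits, which a 4-chlorophenyl or 2-(trifluoromethyl)phenyl group, or an amine on the same phenyl ring, could help to test. No measurement shown here explains why the number moves in this way.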